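The source may report more compounds than this note shows. Statements on the series, on what has been measured and on what is new or still open speak of the compounds shown alone.

In an ADME assay on HUVEC cells (Homo sapiens) for antiproliferative activity, read by MTT assay, with a stated time of 48 h (on this read-out higher numbers stand for weaker inhibition and lower numbers for stronger inhibition), compound 3 `Cc1ccc(-n2nncc2CN2C(=O)C3(C(C#N)=C(N)Oc4c3c3nc5ccccc5nc3c3ccccc43)c3ccccc32)cc1C` gives > 50000 nM, which is a limit of the assay. Compound 1 `N#CC1=C(N)Oc2c(c3nc4ccccc4nc3c3ccccc23)C12C(=O)N(Cc1cnnn1-c1cccc(Cl)c1)c1ccccc12` likewise gives > 50000 nM, also a limit. Compound 2 `N#CC1=C(N)Oc2c(c3nc4ccccc4nc3c3ccccc23)C12C(=O)N(Cc1cnnn1-c1cccc(S(N)(=O)=O)c1)c1ccccc12` gives 38600 nM. Two of the three values sit at the limit (the limit of > 50000 nM in this assay, at which 2 of the 3 values shown sit). The step that the two limits leave unreadable from compound 1 to compound 3 cannot be sized; the step of an at least 1.2-fold higher number from compound 2 to compound 3 (0.11 log units; that floor lies within the scatter) and the step of an at least 1.2-fold lower number from compound 1 to compound 2 (0.11 log units; that floor lies within the scatter) are only floors, each within the scatter. Compound 4 `N#CC1=C(N)Oc2c(c3nc4ccccc4nc3c3ccccc23)C12C(=O)N(Cc1cnnn1-c1cc(Cl)ccc1Cl)c1ccccc12` carries 2,5-dichlorophenyl in place of 3,4-dimethylphenyl on an aromatic nitrogen. All three measured steps change the group on that same aromatic nitrogen, and none shows a move beyond the scatter, so no step beyond the scatter is expected from compound 3 to compound 4 a step that the limit leaves unreadable from compound 3 to compound 4 in this assay. Compound 4 is estimated at 60000 nM, in a range from 30000 nM to 150000 nM, most likely again reported only as a limit.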

Compound 4, half-maximal inhibitory concentration: > 50000 nM
Compound 4: only a limit was reported (the forecaster's own chance of this, stated with the estimate: 70%); the middle value does not contradict the limit.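

In this assay compound 4, with 2,5-dichlorophenyl on the aromatic nitrogen of the five-membered ring, gives > 50000 nM, which is a limit. Within the data shown here, the one readable new step is an at least 1.2-fold higher number from compound 2 to compound 4 (0.11 log units; that floor lies within the scatter). The steps between values that are both limits cannot be read, and a third aryl group at this position now sits at the limit: the limit of > 50000 nM in this assay, at which 3 of the 4 values shown sit.

Open, going by these compounds, is whether an amine or a carboxylic acid on this phenyl ring would give a value clear of the limit. Also open, on these data alone, is whether the sulfamoyl group of compound 2, at 38600 nM, truly differs from the others.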